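A few compounds are considered here, and "the series" means these few. Any claim that something is new, unique, unknown or untested is made for them only; others in the source may bear on it.

Compound 1 `OC[C@H]1O[C@@H](n2cnc3c(NCc4ccc(Cl)cc4)ncnc32)[C@H](O)[C@@H]1O` was tested in a functional assay on MCF cells (Homo sapiens) for antiproliferative activity, with a stated time of 72 h; on this read-out higher numbers stand for weaker inhibition and lower numbers for stronger inhibition. In this assay compound 1 gives no number but only a limit, > 166000 nM. Compound 2 `OC[C@H]1O[C@@H](n2cnc3c(NCc4c(F)ccc(F)c4F)ncnc32)[C@H](O)[C@@H]1O` differs from compound 1 by 2,3,6-trifluorophenyl in place of 4-chlorophenyl on a saturated chain carbon bound to a nitrogen on an aromatic ring. In this assay compound 2 also gives only a limit, > 166000 nM. The step that the two limits leave unreadable from compound 1 to compound 2 cannot be sized because the limit of > 166000 nM in this assay, at which 2 of the 2 values shown sit, covers both of the values shown; compound 1 thus stands at a limit, with no number to compare against.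

Compound 3 `OC[C@H]1O[C@@H](n2cnc3c(NCc4ccccc4OC(F)F)ncnc32)[C@H](O)[C@@H]1O` has not yet been measured in this assay. It differs from compound 1 as follows: 2-(difluoromethoxy)phenyl in place of 4-chlorophenyl on a saturated chain carbon bound to a nitrogen on an aromatic ring. Going by the values given here, only one measured step touches the same place in the molecule, the step that the two limits leave unreadable from compound 1 to compound 2, and it offers no readable size. The change is therefore expected to give a step that the limit leaves unreadable from compound 1 to compound 3, with no direction beyond the scatter. Compound 3 is estimated at 200000 nM, in a range from 50000 nM to 1000000 nM, and most probably it too will return only a limit.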

Compound 3, half-maximal inhibitory concentration: > 166000 nM
Compound 3 was reported as a limit; the forecaster's own chance of this, stated with the estimate: 85%; the middle value does not contradict the limit.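

Compound 3 gives only a limit in this assay, so no step linking it to compound 1 or compound 2 can be read, because all three compounds sit at the same limit: the limit of > 166000 nM in this assay, at which 3 of the 3 values shown sit.

The compounds shown leave open how 4-chlorophenyl, 2,3,6-trifluorophenyl and 2-(difluoromethoxy)phenyl rank against one another, and whether any group at this place gives a measurable number.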